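The compounds below may be only part of what the source reports. "The series", "measured", "known", "first", "only" and "open" are said of these compounds alone.

Compound 1 `CCc1nc(-c2ccc(Cl)cc2Cl)c(CC)nc1NC(C1CC1)C1CC1` gives 3.7 nM in an assay on IMR-32 cells for displacement of a labelled ligand from corticotropin-releasing factor receptor 1 (Homo sapiens), read by scintillation counting, with a stated time of 2 h; a higher number here means a weaker inhibitor, a lower number a stronger inhibitor.
Compound 2 `CCc1nc(N(CC2CC2)CC2CC2)c(CC)nc1-c1ccc(Cl)cc1Cl` gives 26 nM in this assay.
Compound 3 `CCCN(CCN(C)C)c1nc(CC)c(-c2ccc(Cl)cc2Cl)nc1CC` gives 1540 nM in this assay.

Compound 3 has the highest number of the three and is therefore the weakest inhibitor here; its steps to both other compounds lie beyond the scatter, a 59-fold higher number from compound 2 to compound 3 (1.77 log units; beyond the scatter) and a 420-fold higher number from compound 1 to compound 3 (2.62 log units; beyond the scatter). Compound 4 `CCc1nc(-c2ccc(Cl)cc2Cl)c(CC)nc1SC(C)CC` is derived from it by a single change: (sec-butyl)sulfanyl in place of (2-(dimethylamino)ethyl)(propyl)amino on an aromatic carbon. The measured steps bear on this only in part. They show that the group at this position matters strongly: moving from the dicyclopropylmethylamino to the bis(cyclopropylmethyl)amino group cost a modest amount, a 7.0-fold higher number from compound 1 to compound 2 (0.85 log units; beyond the scatter), while moving on to the (2-(dimethylamino)ethyl)(propyl)amino group cost much more. Within the data shown here, no measured step replaces the amino linkage with a sulfanyl one, so the direction is uncertain. Since the departing group belongs to the weakest compound, a recovery of some potency is expected, a 10-fold lower number from compound 3 to compound 4 (1.01 log units; beyond the scatter), though smaller than the gap back to compound 1. Compound 4 is therefore estimated at 150 nM, within 25 nM to 900 nM.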

Compound 4, inhibition constant: 401 nM
Estimate against measurement, compound 4: 2.7-fold (0.43 log units) below, and the stated range covers the measured number.
By their numbers in this assay, from the lowest: compound 1; then compound 2; then compound 4; then compound 3.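

Among these compounds, the step of a 3.8-fold lower number from compound 3 to compound 4 (0.58 log units; beyond the scatter) in this assay gives the first reading of a sulfur link at this position: (sec-butyl)sulfanyl, with no nitrogen on the aromatic carbon, is accepted and ranks ahead of the (2-(dimethylamino)ethyl)(propyl)amino group. It still falls well short of both cyclopropyl-bearing amino groups, with a 15-fold higher number from compound 2 to compound 4 (1.19 log units; beyond the scatter) and a 110-fold higher number from compound 1 to compound 4 (2.03 log units; beyond the scatter) showing that this sulfanyl group does not restore the potency they give. No supporting measurement is available to explain these gaps.

The linking atom and the attached chain differ together in each of these steps, so their separate contributions remain unresolved. A sec-butylamino group or a (dicyclopropylmethyl)sulfanyl group on the shared core would separate them, and a sec-butoxy group would extend the comparison to an oxygen link.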